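A few compounds are considered here, and "the series" means these few. Any claim that something is new, unique, unknown or untested is made for them only; others in the source may bear on it.

Compound 1 `CC(=O)Oc1ccc(C(=O)Nc2cc3ccc(OC4CCN(C)CC4)c(C)c3oc2=O)cc1`: 1670 nM
Compound 2 `CC(=O)Oc1ccc(C(=O)Nc2cc3ccc(OC4CCN(C)CC4)c(C)c3oc2=O)cc1Cl`: 3500 nM

Within the data shown here, in a functional assay on SK-BR-3 cells (Homo sapiens) for antiproliferative activity (a lower number here means a stronger inhibitor, a higher number a weaker inhibitor), compound 2 gives 3500 nM, the higher of the two numbers measured so far, which makes it the weaker inhibitor of the pair. Compound 3 `C=CCc1cc(C(=O)Nc2cc3ccc(OC4CCN(C)CC4)c(C)c3oc2=O)ccc1O` is the next to consider. The structural change is 3-allyl-4-hydroxyphenyl in place of 4-acetoxy-3-chlorophenyl on a carbonyl carbon. Among the measured compounds shown here, only one measured step bears on this, the modest 2.1-fold higher number from compound 1 to compound 2 (0.32 log units; beyond the scatter), seen with chloro in place of hydrogen on an aromatic carbon. Compound 3 carries no chloro, so that step may be partly undone, and a modest move towards a lower number in this assay is expected. For the measured compounds named here, the rest of the change has no measured step, so the uncertainty is wide. The expected change is a 1.9-fold lower number from compound 2 to compound 3 (0.29 log units; within the scatter). Compound 3 is estimated at 1800 nM, with an expected range of 500 nM to 6000 nM.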

Compound 3, half-maximal inhibitory concentration: 2430 nM
Beside the measured number, compound 3's estimate is 1.4-fold (0.13 log units) below it; low and high end bracket the measured number.
By their numbers in this assay, from the lowest: compounds 1, 3 and 2 (each within the scatter of the next, the first and the last beyond it).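

In this assay the exchange of the whole aryl group on the carbonyl carbon gives a 1.4-fold lower number from compound 2 to compound 3 (0.16 log units; within the scatter) and a 1.5-fold higher number from compound 1 to compound 3 (0.16 log units; within the scatter), so neither step separates compound 3 from the compound it is compared with. Among these compounds, the position thus takes 3-allyl-4-hydroxyphenyl, a group with neither acetoxy nor chloro, with no change beyond the scatter from either compound, even though the single chloro step was printed as beyond it. Nothing at hand says what lies behind this result.

The allyl and the hydroxy enter together, so the compounds shown leave open what each does alone. Also open, as far as these compounds go, is whether an amine or a carboxylic acid in place of the hydroxy, or a longer chain in place of the allyl, would move the number beyond the scatter.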